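Cinnamamide analogues on a shared core: chloro for methoxy

The compounds below may be only part of what the source reports. "The series", "measured", "known", "first", "only" and "open" are said of these compounds alone.

Measured compounds:
- compound 2 `O=C(C/C=C/c1ccccc1)Nc1nc2ccccc2c(=O)s1`: 361 nM
- compound 3 `COc1cccc(/C=C/C(=O)Nc2nc3ccccc3c(=O)s2)c1`: 281 nM
- compound 1 `CN(C(=O)CCCc1ccccc1)c1nc2ccccc2c(=O)s1`: "not determined" (no result reported)

All three share one core; they differ only in the acyl side chain and, in compound 1, in the methyl on the amide nitrogen. In an assay on mitochondria (strain Sprague-Dawley) for inhibition of Amine oxidase [flavin-containing] B (Rattus norvegicus), read by fluorescence and Amplex Red, with stated times of 30 min and 45 min (a higher number here means a weaker inhibitor, a lower number a stronger inhibitor), compound 3 gives 281 nM and compound 2 gives 361 nM. Compound 3 has the lower of the two numbers, but the gap to compound 2 lies within the scatter, so the two cannot be ordered on these figures. For compound 1 no number was obtained.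

Compound 4 `O=C(/C=C/c1cccc(Cl)c1)Nc1nc2ccccc2c(=O)s1` is the next entry. Relative to compound 3 the change is chloro in place of methoxy on an aromatic carbon; read one bond further out, it is 3-methoxyphenyl to 3-chlorophenyl. Among the compounds with values here, no measured pair isolates this change, so the expectation rests only on compound 3 and the size of the change, which is a single-atom swap on the outer ring. In this assay the step from compound 3 to compound 4 is expected to be small, if anything toward a lower number, and likely within the scatter, a 1.5-fold lower number from compound 3 to compound 4 (0.17 log units; within the scatter). Compound 4 is therefore estimated at 190 nM, within 70 nM to 520 nM.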

Compound 4, half-maximal inhibitory concentration: 815 nM
Beside the measured number, compound 4's estimate is 4.3-fold (0.63 log units) below it; the whole stated range lies below it.
By their numbers in this assay, from the lowest: compounds 3 and 2 (each within the scatter of the next); then compound 4.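

In this assay the swap of 3-methoxyphenyl to 3-chlorophenyl gives a 2.9-fold higher number from compound 3 to compound 4 (0.46 log units; beyond the scatter) and so shows that this aromatic carbon of the outer ring is not indifferent to the group it carries. Among the compounds shown, this is the only step between two compounds that differ in one place, so it is the first reading of this position, and it is modest in size and runs toward the weaker inhibitor. Nothing on hand bears on what lies behind the step.

One pair cannot tell whether the higher number goes with the departure of methoxy, with its 1 hydrogen-bond acceptor, or with the arrival of chloro, and a hydroxy, a methyl or a fluoro on the same aromatic carbon, or an unsubstituted phenyl on the same side chain, would help to separate the two. The side chain and the methyl on the amide nitrogen remain unread, since compound 2 and compound 3 differ in more than one place from the other compounds and compound 1 has no number.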